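Acetyl-to-propylcarbonyl step on the piperazine amide of the shared core

The compounds below may be only part of what the source reports. "The series", "measured", "known", "first", "only" and "open" are said of these compounds alone.

Measured compounds:
- compound 1, `CC(Nc1nnc2nncn2n1)C(=O)O`: > 100000 nM in a functional assay on MCF7 cells (Homo sapiens) for inhibition, read by MTT assay, with a stated time of 72 h; on this read-out higher numbers stand for weaker inhibition and lower numbers for stronger inhibition
- compound 2, `CC(=O)N1CCN(c2nnc3nncn3n2)CC1`: 13900 nM in this assay
- compound 3, `CN(C)c1nnc2nncn2n1`: 7760 nM in this assay

The shared core carries three different amine substituents across compounds 1 to 3. For compound 1 the value in this assay is a limit of the assay and not a number (the limit of > 100000 nM in this assay, at which 1 of the 3 values shown sits). Among the two numbers that are given, compound 2 stands highest, with compound 3 nearest; the gap between compound 2 and compound 3 lies within the scatter, so no order between these two can be read from the numbers.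

Compound 4, `CCCC(=O)N1CCN(c2nnc3nncn3n2)CC1`, has not yet been measured in this assay. Its difference from compound 2 is ethyl in place of hydrogen on a saturated chain carbon bound to a carbonyl carbon. For the measured compounds named here, no step between measured compounds touches the amide substituent, so the size of this change in this assay cannot be read from the data at hand. With no step beyond the scatter within the two numbers shown, the expectation for compound 4 is a value close to that of compound 2, the step from compound 2 to compound 4 estimated at a 1.2-fold lower number from compound 2 to compound 4 (0.06 log units; within the scatter), in no particular direction beyond the scatter. Compound 4 is therefore expected to give about 12000 nM in this assay, estimated between 4500 nM and 32000 nM.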

Compound 4, half-maximal inhibitory concentration: 6910 nM
The estimate for compound 4 lay 1.7-fold (0.24 log units) above the measured number; measured number inside the range.
By their numbers in this assay, from the lowest: compounds 4, 3 and 2 (each within the scatter of the next). At a limit, above all of these: compound 1.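

For the compounds shown here, this is the first step that touches the amide substituent: in this assay, ethyl in place of hydrogen on a saturated chain carbon bound to a carbonyl carbon gives a 2.0-fold lower number from compound 2 to compound 4 (0.30 log units; within the scatter). With the step printed as within the scatter, the change from acetyl to propylcarbonyl sets no order between the two compounds, and neither a gain nor a loss can be assigned to the longer acyl chain at this position. No measured property shown here bears on this step.

As far as these compounds go, whether a longer chain, a phenyl ring or a carboxylic acid at this same carbon would move the number beyond the scatter stays open, as a single step within the scatter gives neither a direction nor a trend for the position. From the compounds shown here alone, compound 1 gives > 100000 nM, a limit of the assay and not a number, and the other steps among the amine substituents on the shared core cannot be read, so the effect of replacing the acylated piperazine itself also stays open.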